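A few compounds are considered here, and "the series" means these few. Any claim that something is new, unique, unknown or untested is made for them only; others in the source may bear on it.

Measured in a toxicity assay on WI-38 cells (Homo sapiens) for inhibition, read by MTT assay, with a stated time of 72 h; a lower number here means a stronger inhibitor, a higher number a weaker inhibitor:
Compound 1 `O=C(NCc1ccc(NC(=O)c2cc(-c3ccccc3)ccc2N2CCCC2)cc1)OCc1cccnc1`: > 100000 nM
Compound 2 `O=C(NCc1ccc(NC(=O)c2cccc(F)c2N2CCCC2)cc1)OCc1cccnc1`: > 100000 nM
Compound 3 `Cc1cccc(C(=O)Nc2ccc(CNC(=O)OCc3cccnc3)cc2)c1N1CCCC1`: > 100000 nM

Compound 1 stands at > 100000 nM, which is a limit of the assay and not a number. The same holds across the series, with the limit of > 100000 nM in this assay, at which 3 of the 3 values shown sit. Compound 4 `O=C(NCc1ccc(NC(=O)c2cc(C(F)(F)F)ccc2N2CCCC2)cc1)OCc1cccnc1` carries trifluoromethyl in place of phenyl on an aromatic carbon, para to a pyrrolidin-1-yl group: trifluoromethyl in place of phenyl on an aromatic carbon. Among the compounds with values here, the only measured step, a step that the two limits leave unreadable from compound 2 to compound 3, concerns a different exchange and has no readable size. With compound 1, compound 2 and compound 3 all resting on (the limit of > 100000 nM in this assay, at which 3 of the 3 values shown sit), no step beyond the scatter is expected in this assay. The estimated change is a step that the limit leaves unreadable from compound 1 to compound 4. Compound 4 is expected at 120000 nM, with an estimated range of 60000 nM to 300000 nM.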

Compound 4, half-maximal inhibitory concentration: > 100000 nM
Compound 4: no number, only a limit; the forecaster's own chance of this, stated with the estimate: 85%; the middle value is on the limit's open side.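

No step can be read between compound 1 and compound 4: in this assay both values are limits of the assay, not numbers. The compounds shown leave open whether trifluoromethyl and phenyl differ at all here, and what number any of the compounds would give.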